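Swapping methoxy for dimethylamino in compound 2

The source may hold more compounds than are shown below. What is called first, only, known or untested is meant among the compounds shown, and "the series" means these compounds.

Compound 1 `O=C(/C=C/c1cccs1)c1cccc(NC(=O)c2cc(-c3ccncc3)n[nH]2)c1`: 70000 nM
Compound 2 `COc1ccc(/C=C/C(=O)c2cccc(NC(=O)c3cc(-c4ccncc4)n[nH]3)c2)cc1`: 54600 nM

In a functional assay, read by spectrophotometry, tested at 100 uM (on this read-out lower numbers stand for stronger inhibition and higher numbers for weaker inhibition), compound 2 gives 54600 nM, which lies within the usual scatter of repeated measurements from compound 1 at 70000 nM. Neither compound can be ranked above the other. Compound 3 `CN(C)c1ccc(/C=C/C(=O)c2cccc(NC(=O)c3cc(-c4ccncc4)n[nH]3)c2)cc1` differs from compound 2 in one place: dimethylamino in place of methoxy on an aromatic carbon. Dimethylamino stands in place of methoxy on an aromatic carbon, para to a large group.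

Among the measured compounds shown here, only one measured step bears on this change: a 1.3-fold lower number from compound 1 to compound 2 (0.11 log units; within the scatter). It introduced the 4-methoxyphenyl group that is now being altered, and it stayed within the scatter. For the measured compounds named here, no measured compound carries dimethylamino, so the evidence is thin, and no step beyond the scatter is expected in this assay. The expected step is a 1.1-fold lower number from compound 2 to compound 3 (0.04 log units; within the scatter). The estimated value for compound 3 is 50000 nM, with an expected range of 20000 nM to 100000 nM.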

Compound 3, half-maximal inhibitory concentration: 60900 nM
Estimate against measurement, compound 3: 1.2-fold (0.09 log units) below; the range from low to high includes it.
By their numbers in this assay, from the lowest: compounds 2, 3 and 1 (each within the scatter of the next).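

In this assay the change to dimethylamino on this aromatic carbon, para to a large group, gives a 1.1-fold higher number from compound 2 to compound 3 (0.05 log units; within the scatter) and so leaves the read-out where methoxy had it. Taken from the other side, 4-(dimethylamino)phenyl in place of thiophen-2-yl gives a 1.1-fold lower number from compound 1 to compound 3 (0.06 log units; within the scatter) here, which means that all three groups tried at this end of the molecule now read alike within the scatter, and this position has yet to show any measurable response to a change. No measurement shown here offers an explanation for this flat result.

Still open, on these data alone, is whether a carboxylic acid or a primary amine on this same aromatic carbon would produce a step beyond the scatter. A change elsewhere on the shared core might also do so.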